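Methyl in place of nitro on a dienone side chain

This account rests on a few compounds, and the source may have more. Where it says the series, first, only, none or still open, it means among the compounds named here.

Compound 1 `CC1=CCCC(C)(C)C1/C=C/C(=O)/C=C/c1cccc(C(F)(F)F)c1`: 5200 nM
Compound 2 `CC1=CCCC(C)(C)C1/C=C/C(=O)/C=C/c1cccc([N+](=O)[O-])c1`: 2900 nM

Of the compounds shown here, two sharing one core have been measured in a functional assay on PC-3 cells (Homo sapiens) for cytotoxicity, read by MTT assay, with a stated time of 72 h; on this read-out higher numbers stand for weaker inhibition and lower numbers for stronger inhibition. Compound 1 `CC1=CCCC(C)(C)C1/C=C/C(=O)/C=C/c1cccc(C(F)(F)F)c1` carries a trifluoromethyl group on its aromatic ring and gives 5200 nM in this assay. Compound 2 `CC1=CCCC(C)(C)C1/C=C/C(=O)/C=C/c1cccc([N+](=O)[O-])c1` carries a nitro group in its place and gives 2900 nM in this assay. The two numbers sit within the scatter of each other, separated only by a 1.8-fold lower number from compound 1 to compound 2 (0.25 log units; within the scatter), so compound 2 cannot be set apart from compound 1 on these data.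

Compound 3 `CC1=CCCC(C)(C)C1/C=C/C(=O)/C=C/c1cccc(C)c1` is not yet measured. It differs from compound 2 by methyl in place of nitro on an aromatic carbon. Among the compounds with values here, the only step that bears on this change is the exchange of one aromatic substituent for another, a 1.8-fold lower number from compound 1 to compound 2 (0.25 log units; within the scatter), and that step stayed within the scatter. A second exchange at the same place is therefore expected to give no step beyond the scatter in this assay, in either direction. Compound 3 is estimated at 4000 nM in this assay, with a range from 1500 nM to 10000 nM, which amounts to an expected step of a 1.4-fold higher number from compound 2 to compound 3 (0.14 log units; within the scatter).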

Compound 3, half-maximal inhibitory concentration: 5900 nM
Compound 3: middle estimate off by 1.5-fold (0.17 log units), on the low side; the range from low to high includes it.
By their numbers in this assay, from the lowest: compounds 2, 1 and 3 (each within the scatter of the next, the first and the last beyond it).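

In this assay, the exchange of nitro for methyl on this aromatic carbon gives a 2.0-fold higher number from compound 2 to compound 3 (0.31 log units; beyond the scatter), a modest step and the first at this place to pass the scatter, where the earlier exchange of trifluoromethyl for nitro had not. Methyl in place of trifluoromethyl at the same carbon gives a 1.1-fold higher number from compound 1 to compound 3 (0.05 log units; within the scatter), so these two groups cannot be told apart here, and the three groups do not fall into three separate levels: only the pair of nitro and methyl stands apart, and only narrowly. Nothing available bears on what lies behind this small separation.

The compounds shown leave open how an amine, a carboxylic acid or a longer chain such as propyl would read at this aromatic carbon, and whether any of them would move the number further than the modest step seen here. They also leave open whether methyl in place of nitro would give a step of similar size at another carbon of the aromatic ring or on a different core.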